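Replacing the benzyl of compound 1 with a morpholine carbonyl

The compounds below may be only part of what the source reports. "The series", "measured", "known", "first", "only" and "open" are said of these compounds alone.

compound 1 `O=c1ccc(-c2ccc3cn[nH]c3c2)cn1Cc1ccccc1`, in an assay for inhibition of MAP kinase-interacting serine/threonine-protein kinase 1 (Homo sapiens), read by luminescence and ADP-Glo, with a stated time of 2 h; a higher number here means a weaker inhibitor, a lower number a stronger inhibitor: 315 nM
compound 2 `NC(=O)c1ccccc1Cn1cc(-c2ccc3cn[nH]c3c2)ccc1=O`: 878 nM
compound 3 `Cn1ncc2ccc(-c3ccc(=O)n(Cc4ccccc4)c3)cc21`: only a limit of this assay, > 2000 nM

Of the two numbers reported, compound 1 stands lowest; its nearest neighbour is compound 2, with a 2.8-fold higher number from compound 1 to compound 2 (0.45 log units; beyond the scatter). Compound 3 sits at the limit described by the limit of > 2000 nM in this assay, at which 1 of the 3 values shown sits. From that limit follows an at least 6.3-fold higher number from compound 1 to compound 3 (0.80 log units; beyond the scatter).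

Compound 4 `O=C(N1CCOCC1)n1cc(-c2ccc3cn[nH]c3c2)ccc1=O` has not yet been measured in this assay. It differs from compound 1 by (morpholin-4-yl)carbonyl in place of benzyl on an aromatic nitrogen. Neither measured step touches the benzyl, so both bear only loosely on this change; each of them, however, raised the number, one modestly and one at least modestly. The change in compound 4 removes the benzyl altogether, a larger alteration than either measured step, so a rise beyond the scatter is expected, in the direction of weaker inhibition. Compound 4 is therefore estimated at 1200 nM, with a range of 400 nM to 4000 nM. That estimate corresponds to an expected 3.8-fold higher number from compound 1 to compound 4 (0.58 log units; beyond the scatter).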

Compound 4, half-maximal inhibitory concentration: > 2000 nM
Compound 4: no number, only a limit (the forecaster's own chance of this, stated with the estimate: 30%); middle value at least 1.6-fold (0.22 log units) away from the limit.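

In this assay compound 4 gives only a limit, > 2000 nM. Going by these compounds alone, replacing benzyl with (morpholin-4-yl)carbonyl on the aromatic nitrogen gives an at least 6.3-fold higher number from compound 1 to compound 4 (0.80 log units; beyond the scatter), and unlike the earlier steps, which kept the benzyl or added to it, this one shows what happens when the benzyl itself goes: an entering group with a non-aromatic ring and a carbonyl does not keep the number of compound 1. Compound 3 and compound 4 cannot be ranked against each other, since both stop at the same limit: the limit of > 2000 nM in this assay, at which 2 of the 4 values shown sit.

The compounds shown do not separate the loss of the aromatic ring from the arrival of the carbonyl on that nitrogen. A benzoyl group there would keep the aromatic ring with the carbonyl, while a 2-(morpholin-4-yl)ethyl chain would keep the morpholine without it.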